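Replacing methyl on the aromatic ring of compound 3

A few compounds are considered here, and "the series" means these few. Any claim that something is new, unique, unknown or untested is made for them only; others in the source may bear on it.

compound 1 `COc1ccc(N(C)c2nc(C)nc3c2nc(C)n3C)cc1` gives 6200 nM
compound 2 `COc1ccc(Nc2nc(C)nc3c2nc(C)n3C)cc1` gives > 250000 nM as a limit of the assay
compound 3 `Cc1ccc(N(C)c2nc(C)nc3c2nc(C)n3C)cc1` gives 164000 nM

In a functional assay on CCRF-CEM cells (Homo sapiens) for inhibition, read by cell counting, with a stated time of 96 h (on this read-out lower numbers stand for stronger inhibition and higher numbers for weaker inhibition), compound 3 gives 164000 nM as the higher of the two true numbers, and its nearest neighbour lies beyond the scatter, with a 26-fold higher number from compound 1 to compound 3 (1.42 log units; beyond the scatter) as the gap. Compound 4 `Cc1nc(N(C)c2ccc(OC(F)(F)F)cc2)c2nc(C)n(C)c2n1` carries trifluoromethoxy in place of methyl on an aromatic carbon, para to a large group (trifluoromethoxy in place of methyl on an aromatic carbon). That large step on the same carbon is the closest guide. The step of an at least 40-fold higher number from compound 1 to compound 2 (1.60 log units; beyond the scatter) concerns a nitrogen and bears only on the core. Within the data shown here, compound 4 keeps an oxygen on that carbon, as does compound 1 at 6200 nM in this assay and a lower number than compound 3 is therefore expected, although no measured step covers fluorine. The expected change is a 5.5-fold lower number from compound 3 to compound 4 (0.74 log units; beyond the scatter) in this assay and it is beyond the scatter. For compound 4 the estimate is 30000 nM with an expected range from 6000 nM to 150000 nM here.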

Compound 4, half-maximal inhibitory concentration: 132000 nM
Compound 4: the middle estimate sits 4.4-fold (0.64 log units) below what was measured; the measured number falls inside the stated range.
By their numbers in this assay, from the lowest: compound 1; then compounds 4 and 3 (each within the scatter of the next). At a limit, above all of these: compound 2.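

In this assay, keeping an oxygen on this aromatic carbon does not by itself bring back the number of compound 1: trifluoromethoxy in place of methyl gives a 1.2-fold lower number from compound 3 to compound 4 (0.09 log units; within the scatter) and so separates compound 4 from compound 3 by no more than the scatter. Among these compounds the low number goes with methoxy alone, since trifluoromethyl in place of methyl on that oxygen gives a 21-fold higher number from compound 1 to compound 4 (1.33 log units; beyond the scatter) and the oxygen stays in place. As far as these compounds go, how ethoxy, a hydroxyl or an amine on this carbon would read remains open. Nothing shown gives a cause for the loss seen with fluorine on that methyl.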